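This account rests on a few compounds, and the source may have more. Where it says the series, first, only, none or still open, it means among the compounds named here.

Among the compounds with values here, compound 1 `CC[C@H](c1ccc(C(=O)O)c(Oc2cccc(Cl)c2)c1OC)N1CCC[C@H](n2cc(C)c(=O)[nH]c2=O)C1` is the only member of this small series with a number in an ADME assay on a cell-free system (plasma, Mus musculus) for protein binding, using equilibrium dialysis, with a stated time of 5 h, tested at 10 uM (a lower number here means a smaller unbound share, a higher number a larger unbound share of the compound), where compound 1 gives 0.006. With nothing to compare it against, that figure cannot yet be called high or low within the series. Two close relatives offer no help: for compound 2 `CC[C@H](c1ccc(C(=O)O)c(Oc2cccc(Cl)c2)c1F)N1CCC[C@H](n2cc(C)c(=O)[nH]c2=O)C1` the entry reads "not determined" (no result reported), and for compound 3 `CCC[C@H](c1ccc(C(=O)O)c(Oc2cccc(Cl)c2)c1OC)N1CCC[C@H](n2cc(C)c(=O)[nH]c2=O)C1` it reads "not determined" (no result reported). Still unmeasured is compound 4 `CC[C@@H](c1ccc(C(=O)O)c(Oc2cccc(Cl)c2)c1OC)N1CCC[C@H](n2cc(C)c(=O)[nH]c2=O)C1`. Its change from compound 1 is a subtle one: the two compounds have the same atoms and bonds and differ only in configuration as drawn: 1 of 2 stereo elements differ; a stereocentre at a saturated chain carbon is drawn R in compound 1 and S in compound 4. A stereocentre at a saturated chain carbon is drawn R in compound 1 and S in compound 4. Within the data shown here, no measured pair here shows what such a switch does to this assay. No step beyond the usual scatter is expected, and neither direction is favoured. The expected change is small, a 1.2-fold higher number from compound 1 to compound 4 (0.07 log units; within the scatter). For compound 4 the estimated value is 0.007, with an expected range from 0.003 to 0.015.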

Compound 4, unbound fraction: 0.011
Beside the measured number, compound 4's estimate is 1.6-fold (0.20 log units) below it; low and high end bracket the measured number.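

Within the data shown here, the first measured pair in this assay shows a 1.8-fold higher number from compound 1 to compound 4 (0.26 log units; within the scatter). The drawn configuration at this saturated chain carbon therefore gives no difference in unbound fraction that can be told apart from repeat measurements. This is a reading from a single pair, but it is a clean comparison, as nothing else separates the two structures: the fact that compounds 1 and 4 differ only in the configuration as drawn

Still open, as far as these compounds go, is whether configuration at this carbon would count for as little with a different group attached there, such as a cyclopropyl group, or in a compound carrying an amide in place of the carboxylic acid. The second stereo element is also unresolved, as it is drawn the same way in compound 1 and compound 4, so its part in the unbound fraction cannot be read from this pair.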